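The source may hold more compounds than are shown below. What is called first, only, known or untested is meant among the compounds shown, and "the series" means these compounds.

Measured compounds:
compound 1, `Cc1ccc2oc(SCC(=O)Nc3ccc(-c4nc(-c5ccccc5)c(-c5ccccc5)n4C)cc3)nc2c1`: 37.7%
compound 2, `Cn1c(-c2ccc(NC(=O)CSc3nc4ccccc4s3)cc2)nc(-c2ccccc2)c1-c1ccccc1`: 47.2%
compound 3, `CCN1CCN(CC(=O)Nc2ccc(-c3nc(-c4ccccc4)c(-c4ccccc4)n3C)cc2)CC1`: 28.4%

All three were tested in a functional assay on HT-29 cells (Homo sapiens) for cytotoxicity, read by MTT assay, with a stated time of 24 h, tested at 16 ug/mL; a lower number here means a weaker effect, a higher number a stronger effect of the compound at the concentration tested. Compound 3 gives the lowest of the three numbers, but only its step from compound 2 is telling: a number 18.8 percentage points lower from compound 2 to compound 3 (beyond the scatter). Against compound 1 the step is smaller, a number 9.3 percentage points lower from compound 1 to compound 3 (within the scatter), and the two values lie within the scatter of each other. Compound 1 and compound 2 differ only at the group on the sulfur, a number 9.5 percentage points higher from compound 1 to compound 2 (within the scatter).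

Compound 4, `Cc1ccc(CN2CCN(CC(=O)Nc3ccc(-c4nc(-c5ccccc5)c(-c5ccccc5)n4C)cc3)CC2)cc1`, is not yet measured. It differs from compound 3 in one place: 4-methylphenyl in place of methyl on a saturated chain carbon bound to an amine nitrogen in a ring. Among the compounds with values here, no measured step touches this position; the two steps that reach compound 3, from compound 1 and from compound 2, replace the whole group on the chain carbon and were small to modest. There is thus no shown step that supports a large move in either direction. Compound 4 is expected to give about 32%, within 20% to 45%. The expected step, a number 3.6 percentage points higher from compound 3 to compound 4 (within the scatter), is estimated to stay within the scatter.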

Compound 4, a percentage reported as activity, at one concentration (the size of the read-out at that concentration, not a potency): 30.6%
Beside the measured number, compound 4's estimate is 1.4 percentage points above it; low and high end bracket the measured number.
By their numbers in this assay, from the lowest: compounds 3, 4, 1 and 2 (each within the scatter of the next, the first and the last beyond it).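

Moving from the methyl to 4-methylphenyl on a saturated chain carbon bound to an amine nitrogen in a ring is the first change measured at this position, and in this assay it gives a number 2.2 percentage points higher from compound 3 to compound 4 (within the scatter). The same difference, read as ethyl to 4-methylbenzyl, adds a six-membered aromatic ring of carbon only and raises the group from one heavy atom to seven, yet compound 3 and compound 4 stay within the scatter of each other. Nothing measured here offers an explanation for this result.

From the compounds shown here alone, whether a carboxylic acid, a primary amine or a longer chain at this place would separate from compound 3 stays open. So does whether a plain phenyl or a 4-fluorophenyl there would give a number apart from that of compound 4.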